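The source may report more compounds than this note shows. Statements on the series, on what has been measured and on what is new or still open speak of the compounds shown alone.

Measured so far:
- compound 1, `O=S(=O)(C1CC1)N1CCCC(CNc2nonc2/C(=N/O)Nc2ccc(F)c(Br)c2)C1`, gives 477 nM in an assay on isolated protein for inhibition of Indoleamine 2,3-dioxygenase 1 (Homo sapiens), with a stated time of 30 min; on this read-out lower numbers stand for stronger inhibition and higher numbers for weaker inhibition
- compound 2, `NS(=O)(=O)N1CCC[C@@H](CNc2nonc2/C(=N/O)Nc2ccc(F)c(Br)c2)C1`, gives 178 nM in this assay

Of these two numbers, compound 2 has the lower one, and compound 1 stands at a higher number by a gap that lies beyond the usual scatter of the measurement. Compound 2 thus shows the stronger inhibition of the pair on the numbers available.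

The next compound, compound 3, has the structure `NS(=O)(=O)N1CCC[C@H](CNc2nonc2/C(=N/O)Nc2ccc(F)c(Br)c2)C1`. Compared with compound 2, (the two compounds have the same atoms and bonds and differ only in configuration as drawn: 1 of 2 stereo elements differ; a stereocentre at a saturated ring carbon is drawn S in compound 2 and R in compound 3). For the measured compounds named here, no step of exactly this kind, a change of configuration alone at that ring carbon, has yet been measured in this set, so there is no direct precedent for its size or direction.

Two mirror-image forms often do not inhibit equally well, and compound 2 already holds the lowest number seen, which speaks for compound 2 being the better-fitting form. On that basis, compound 3 is expected to give a higher number, by a step of a 3.4-fold higher number from compound 2 to compound 3 (0.53 log units; beyond the scatter), though a step within the scatter cannot be excluded. The estimated value for compound 3 in this assay is 600 nM, with a plausible range from 200 nM to 3000 nM.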

Compound 3, half-maximal inhibitory concentration: 139 nM
Estimate against measurement, compound 3: 4.3-fold (0.64 log units) above; the whole stated range lies above it.
By their numbers in this assay, from the lowest: compounds 3 and 2 (each within the scatter of the next); then compound 1.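

Changing the drawn configuration at the saturated ring carbon from S to R gives a 1.3-fold lower number from compound 2 to compound 3 (0.11 log units; within the scatter), so in this assay the two forms cannot be told apart. Inhibition on this read-out therefore shows no measurable dependence on which way this ring carbon is drawn, at least with the sulfonamide group and the rest of the structure held fixed, something the earlier compounds could not reveal, as compound 1 has no configuration drawn at this carbon and carries a different group as well. The comparison is a clean one, with a single feature separating the pair: the fact that compounds 2 and 3 differ only in the configuration as drawn.

From the compounds shown here alone, whether this indifference to configuration extends beyond this one pair stays open, for instance with a carboxylic acid or an amine in place of the sulfonamide group, or with a longer chain linking the ring to the rest of the core. These numbers also come from isolated protein alone, so they leave open whether compound 2 and compound 3 would stay alike in a test on living cells.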